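Swapping Bromo for Fluoro on a Shared Core

This account rests on a few compounds, and the source may have more. Where it says the series, first, only, none or still open, it means among the compounds named here.

Compound 1 `O=C1O/C(=C\Cn2cc(C(F)(F)F)c(=O)[nH]c2=O)C(OCc2ccccc2)=C1OCc1ccccc1`: 1600 nM
Compound 2 `O=C1O/C(=C\Cn2cc(Br)c(=O)[nH]c2=O)C(OCc2ccccc2)=C1OCc1ccccc1`: 3500 nM
Compound 3 `O=C1O/C(=C\Cn2cc(F)c(=O)[nH]c2=O)C(OCc2ccccc2)=C1OCc1ccccc1`: not yet measured

All three compounds share one core and differ only in a single group on one aromatic carbon. For the measured compounds named here, in a functional assay on CCRF-CEM cells (Homo sapiens) for inhibition (on this read-out higher numbers stand for weaker inhibition and lower numbers for stronger inhibition), compound 2 gives 3500 nM, the higher of the two numbers so far, which makes it the weaker of the two measured inhibitors.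

Compound 3 keeps everything else and changes that one group: fluoro in place of bromo on an aromatic carbon. In words, this is fluoro in place of bromo on an aromatic carbon.

Going by the values given here, only one measured step bears on this change, since it involves the same carbon. That step is modest: a 2.2-fold higher number from compound 1 to compound 2 (0.34 log units; beyond the scatter). In that single pair, bromo gave the higher number, so a step of similar modest size towards a lower number seems the best expectation in this assay. One pair cannot settle the direction, however, and fluoro itself has not yet been tested here.

The expected change is a 1.8-fold lower number from compound 2 to compound 3 (0.24 log units; within the scatter). For compound 3, the estimated value is 2000 nM, with an expected range from 600 nM to 6000 nM.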

Compound 3, half-maximal inhibitory concentration: 15100 nM
Estimate against measurement, compound 3: 7.6-fold (0.88 log units) below; measured number above the stated range.
By their numbers in this assay, from the lowest: compound 1; then compound 2; then compound 3.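

In this assay this one aromatic carbon proves more sensitive to its substituent than the first pair could show: replacing bromo with fluoro, one heavy atom for one heavy atom with no change in the hydrogen-bond donor, acceptor or charge counts, gives a 4.3-fold higher number from compound 2 to compound 3 (0.63 log units; beyond the scatter) and is a larger step than the earlier one between trifluoromethyl and bromo. Going directly from trifluoromethyl to fluoro gives a 9.4-fold higher number from compound 1 to compound 3 (0.97 log units; beyond the scatter) and completes an order across the three compounds, with compound 1 the strongest inhibitor, compound 2 in the middle and compound 3 the weakest, each gap lying beyond the usual scatter. Nothing available explains why fluoro is the weakest of the three groups here.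

From the compounds shown here alone, three groups on one carbon give an order but not a rule, so it remains open where a plain hydrogen, a methyl, a nitrile or an amine would fall in that order. Going by these compounds, it is also open whether this order would hold if the rest of the shared core were changed, for instance if a benzyl group gave way to a longer chain.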